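The source may report more compounds than this note shows. Statements on the series, on what has been measured and on what is new or still open speak of the compounds shown alone.

Measured so far:
Compound 1, `COc1ccc(-c2nc(C(=O)/C=C\Nc3ccc(Cl)cc3)c3ccccn23)cc1`: > 30000 nM in a functional assay on HCT-116 cells (Homo sapiens) for cytotoxicity, read by MTT assay, with a stated time of 48 h; a lower number here means a stronger inhibitor, a higher number a weaker inhibitor (this value is a limit of the assay, not a number).
Compound 2, `O=C(/C=C\Nc1ccc2[nH]ccc2c1)c1nc(-c2ccc(C(F)(F)F)cc2)n2ccccc12`: 27100 nM in this assay.

Among the measured compounds shown here, compound 2 holds the only actual number among the two values shown; the value of compound 1 is a limit. The reading for compound 1 sits at the limit of > 30000 nM in this assay, at which 1 of the 2 values shown sits.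

Compound 3, `O=C(/C=C\Nc1ccc(Cl)cc1)c1nc(-c2ccc(C(F)(F)F)cc2)n2ccccc12`, has not yet been measured in this assay. The change from compound 2 to compound 3 is 4-chlorophenyl in place of 1H-indol-5-yl on an amine nitrogen. For the measured compounds named here, no measured pair shows this change on its own, so the size of the step cannot be taken from the data. Since compound 2 already reads close to the limit at which compound 1 sits, compound 3 is expected to fall near that limit as well, with a step from compound 2 to compound 3 of a 1.2-fold higher number from compound 2 to compound 3 (0.07 log units; within the scatter) that is expected to be small. The estimate for compound 3 is 32000 nM, expected to lie between 12000 nM and 80000 nM.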

Compound 3, half-maximal inhibitory concentration: 11500 nM
Compound 3: the middle estimate sits 2.8-fold (0.44 log units) above what was measured; the whole stated range lies above it.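

Among the compounds shown here, on the amine nitrogen, 4-chlorophenyl in place of 1H-indol-5-yl gives the first step that can be read at this position in this assay, with a 2.4-fold lower number from compound 2 to compound 3 (0.37 log units; beyond the scatter), so the 1H-indol-5-yl group is not needed for the activity seen and the reading responds to the group carried there. With 4-chlorophenyl held on the amine nitrogen, trifluoromethyl in place of methoxy on an aromatic carbon gives an at least 2.6-fold lower number from compound 1 to compound 3 (0.41 log units; beyond the scatter), so the change at this second place also registers. The size of that second step is only bounded, since the reading of compound 1 is a limit and not a number: the limit of > 30000 nM in this assay, at which 1 of the 3 values shown sits.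

The compounds shown do not separate the departure of the 1H-indol-5-yl group, with its hydrogen-bond donor, from the entry of chlorine, and how an unsubstituted phenyl or a 4-fluorophenyl on the amine nitrogen would read stays open. Also open, from the compounds shown here alone, is how a nitrile in place of trifluoromethyl on that aromatic carbon would read.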